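The source may report more compounds than this note shows. Statements on the series, on what has been measured and on what is new or still open speak of the compounds shown alone.

Compound 1 `COC(=O)c1cc(-c2cccc(NC(=O)c3ccc(/C=C/C(=O)c4cccc(F)c4)cc3)c2)on1` belongs to a small series built on a shared core. In an ADME assay on Vero cells (Chlorocebus sabaeus) for cytotoxicity, read by MTT assay, with a stated time of 72 h (a lower number here means that less compound is tolerated, a higher number that more compound is tolerated), compound 1 gives > 40 ug/mL, which is a limit of the assay rather than a number. Compound 2 `COC(=O)c1cc(-c2cccc(NC(=O)c3ccc(/C=C/C(=O)c4ccccc4Br)cc3)c2)on1` also gives a limit in this assay, > 40 ug/mL. Compound 3 `COC(=O)c1cc(-c2cccc(NC(=O)c3ccc(/C=C/C(=O)c4cccnc4)cc3)c2)on1` has no result in this assay, recorded as "not determined" (no result reported). For the measured compounds named here, the only step between measured compounds, a step that the two limits leave unreadable from compound 1 to compound 2, cannot be sized, because the limit of > 40 ug/mL in this assay, at which 2 of the 3 values shown sit, holds both values. Compound 4 `COC(=O)c1cc(-c2cccc(NC(=O)c3ccc(/C=C/C(=O)c4ccc(OC)cc4OC)cc3)c2)on1` differs from compound 1 by 2,4-dimethoxyphenyl in place of 3-fluorophenyl on a carbonyl carbon. With no readable step to draw on, compound 4 is expected to sit at the same limit, an estimated 40 ug/mL with a range from 20 ug/mL to 80 ug/mL, so the expected step of a number no higher from compound 1 to compound 4 (the limit leaves the size open) is none beyond the scatter.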

Compound 4, half-maximal cytotoxic concentration: > 50 ug/mL
Compound 4: no number, only a limit (the forecaster's own chance of this, stated with the estimate: 75%); middle value at least 1.2-fold (0.09 log units) away from the limit.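

Compound 4 gives > 50 ug/mL in this assay, which is a limit, and neither the step to it from compound 1 nor the step from compound 2 can be read. From the compounds shown here alone, whether the group on the carbonyl carbon changes how much compound the cells tolerate stays open.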